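The compounds below may be only part of what the source reports. "The series", "measured", "known", "first", "only" and "open" are said of these compounds alone.

Compound 1, `COc1ccc(N(C)c2ccnc(Cl)n2)cc1F`, is the starting point. Among the measured compounds shown here, in a functional assay on HeLa cells (Homo sapiens) for antiproliferative activity, read by MTT assay, with a stated time of 48 h (on this read-out lower numbers stand for stronger inhibition and higher numbers for weaker inhibition), compound 1 gives 241 nM, the lowest of the three numbers measured so far. Compound 3, `COc1ccc(N(C)c2ccnc(Cl)n2)cc1OCCCBr`, gives 307 nM in this assay, and the step of a 1.3-fold higher number from compound 1 to compound 3 (0.11 log units; within the scatter) is small. Compound 2, `COc1ccc(N(C)c2ccnc(Cl)n2)cc1[N+](=O)[O-]`, gives 4730 nM, and the step of a 20-fold higher number from compound 1 to compound 2 (1.29 log units; beyond the scatter) is large, as is a 15-fold lower number from compound 2 to compound 3 (1.19 log units; beyond the scatter).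

The unmeasured compound 4, `COc1ccc(N(C)c2ccnc(Cl)n2)cc1OCCC[Se]C#N`, differs from compound 1 in one place: a group of 7 heavy atoms (4 carbon, 1 nitrogen, 1 oxygen, 1 selenium; no ring) in place of one fluorine atom, on an aromatic carbon. For the measured compounds named here, the step that bears on this change is the one to compound 3, where a 3-bromopropoxy group in place of the same fluorine atom gave a 1.3-fold higher number from compound 1 to compound 3 (0.11 log units; within the scatter); the entering group of compound 4 likewise has no ring and two hydrogen-bond acceptors. Compound 2 shows that a change at this carbon can matter greatly, but its nitro group is unlike the group entering here. Compound 4 is therefore expected to show no step beyond the scatter, a 1.2-fold higher number from compound 1 to compound 4 (0.10 log units; within the scatter). The estimate for compound 4 in this assay is 300 nM, with a range from 120 nM to 800 nM.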

Compound 4, half-maximal inhibitory concentration: 4710 nM
Compound 4: the middle estimate sits 16-fold (1.20 log units) below what was measured, outside the stated range (above it).
By their numbers in this assay, from the lowest: compounds 1 and 3 (each within the scatter of the next); then compounds 4 and 2 (each within the scatter of the next).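

At this aromatic carbon, a three-carbon chain does not by itself decide the outcome: in this assay the 3-bromopropoxy chain of compound 3 stayed within the scatter of compound 1, yet the chain ending in selenium and nitrile gives a 20-fold higher number from compound 1 to compound 4 (1.29 log units; beyond the scatter). What matters is the end of the chain, since exchanging only the bromine gives a 15-fold higher number from compound 3 to compound 4 (1.19 log units; beyond the scatter), and the result sits level with the nitro compound, at a 1.0-fold lower number from compound 2 to compound 4 (0.00 log units; within the scatter). Nothing shown here explains why this chain end costs so much activity.

On these data alone, whether the loss belongs to the selenium, the nitrile or the two together stays open, and a sulfur atom in place of selenium, or a plain nitrile on the same chain, would separate them. Also open, as far as these compounds go, is whether a longer chain, or an amine at the chain end, would stay near compound 1.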